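Chloro for methyl on the shared core: tolerance notes

This account rests on a few compounds, and the source may have more. Where it says the series, first, only, none or still open, it means among the compounds named here.

Compound 1 `COC(=O)[C@H](CO)NC(=O)c1cnc2cc(C)ccc2c1Cl` gives 59.6 uM in an ADME assay on CCRF-CEM cells (Homo sapiens) for cytotoxicity; a lower number here means that less compound is tolerated, a higher number that more compound is tolerated. Compound 3 `COC(=O)[C@H](CO)NC(=O)c1cnc2cc(Cl)ccc2c1Cl` carries chloro in place of methyl on an aromatic carbon relative to compound 1. In this assay compound 3 gives > 100 uM, which is a limit of the assay. The measured step is an at least 1.6-fold higher number from compound 1 to compound 3 (0.22 log units; that floor lies within the scatter), and its floor is set because of the limit of > 100 uM in this assay, at which 2 of the 3 values shown sit.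

Compound 2 `COC(=O)[C@H](CO)NC(=O)c1cnc2ccc(C)cc2c1Cl` rests on a core whose difference from the core of compound 1 is not broken down here. In this assay compound 2 gives > 100 uM, again a limit of the assay.

Compound 4 `COC(=O)[C@H](CO)NC(=O)c1cnc2ccc(Cl)cc2c1Cl` is not yet measured and differs from compound 2 by chloro in place of methyl on an aromatic carbon. The place of the change is described in the same words for both pairs, so this is the same change as from compound 1 to compound 3; among the four compounds it occurs twice.

The step in this assay is expected to be a step that the limit leaves unreadable from compound 2 to compound 4. This expectation rests on compound 1, whose step on the same change was an at least 1.6-fold higher number from compound 1 to compound 3 (0.22 log units; that floor lies within the scatter). It also rests on compound 2, whose reading > 100 uM is already a limit. Compound 4 is therefore expected at 150 uM, with a range from 80 uM to 400 uM, and most likely reported only as a limit.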

Compound 4, half-maximal toxic concentration: > 100 uM
Compound 4: no number, only a limit (the forecaster's own chance of this, stated with the estimate: 85%); the middle value does not contradict the limit.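

The step from compound 2 to compound 4 cannot be read, because in this assay both compounds give a limit of the assay rather than a number: the limit of > 100 uM in this assay, at which 3 of the 4 values shown sit.

The compounds shown leave open whether chloro in place of methyl on an aromatic carbon changes the number in this assay in either pair, and by how much.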